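Sulfanyl to Methylselanyl: What to Expect

This account rests on a few compounds, and the source may have more. Where it says the series, first, only, none or still open, it means among the compounds named here.

Compound 2 `Sc1nc(NCc2ccccc2)c2ccccc2n1` stands in a functional assay on CCRF-CEM cells (Homo sapiens) for cytotoxicity, read by MTT assay, with a stated time of 72 h (a lower number here means a stronger inhibitor of growth, a higher number a weaker inhibitor of growth), only at a limit of the assay, not at a number: compound 2 gives > 100000 nM (the limit of > 100000 nM in this assay, at which 1 of the 2 values shown sits). Compound 1 `CCCCC[Se]c1nc(NCc2ccc(SC)cc2)c2ccccc2n1`, which carries other groups, gives 83900 nM in this assay. Compound 3 `C[Se]c1nc(NCc2ccccc2)c2ccccc2n1` differs from compound 2 by a group of 2 heavy atoms (1 carbon, 1 selenium; no ring) in place of one sulfur atom, on an aromatic carbon. For the measured compounds named here, no measured step of this kind exists, so the move from compound 2 to compound 3 is expected to be an at least 1.1-fold lower number from compound 2 to compound 3 (0.04 log units; that floor lies within the scatter), no larger than the scatter or a modest gain. Compound 3 is estimated at 90000 nM, ranging from 30000 nM to 250000 nM.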

Compound 3, concentration for total growth inhibition: 61600 nM
For compound 3 the middle estimate is 1.5-fold (0.16 log units) above the measured one; low and high end bracket the measured number.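

In this assay, for the compounds shown here, the change from sulfanyl to methylselanyl on the aromatic carbon between two ring nitrogen atoms gives the first step at this position: an at least 1.6-fold lower number from compound 2 to compound 3 (0.21 log units; that floor lies within the scatter). Compound 2 gives > 100000 nM, which is a limit of the assay and not a number. The step is only a floor because one of its ends rests on that limit: the limit of > 100000 nM in this assay, at which 1 of the 3 values shown sits.

As far as these compounds go, whether the true change goes beyond the usual scatter stays open. So does how an amine at this position, or a pentyl chain on the selenium of compound 3, would read.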